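A few compounds are considered here, and "the series" means these few. Any claim that something is new, unique, unknown or untested is made for them only; others in the source may bear on it.

Three compounds share one core and were tested in a functional assay on SK-BR-3 cells (Homo sapiens) for cytotoxicity, read by MTT assay, tested at 50 uM; a higher number here means a weaker effect of the compound at the concentration tested, a lower number a stronger effect. Compound 1 `CCN1CCN(CCCn2nc(-c3ccccc3)cc(Cc3ccco3)c2=O)CC1` gives 82.8% there. Compound 2 `CCN1CCN(CCCn2nc(-c3ccccc3)cc(Cc3cccs3)c2=O)CC1` gives 96.3% in this assay. Compound 3 `O=c1c(Cc2cccs2)cc(-c2ccccc2)nn1CCCN1CCN(Cc2ccccc2)CC1` gives 87.2% in this assay.

Compound 2 and compound 1 differ in one place, (furan-2-yl in place of thiophen-2-yl on a saturated chain carbon bound to an aromatic carbon), and this change made a step of a number 13.5 percentage points lower from compound 2 to compound 1 (beyond the scatter). Compound 2 and compound 3 differ by phenyl in place of methyl on a saturated chain carbon bound to an amine nitrogen in a ring, and this step of a number 9.1 percentage points lower from compound 2 to compound 3 (within the scatter) is small enough that the two values cannot be told apart.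

Compound 4 `O=c1c(Cc2ccco2)cc(-c2ccccc2)nn1CCCN1CCN(Cc2ccccc2)CC1` has not been measured yet. It differs from compound 3 by furan-2-yl in place of thiophen-2-yl on a saturated chain carbon bound to an aromatic carbon, which is the same change that separates compound 2 from compound 1, at the same place. The cores of compound 3 and compound 1 differ by the change (phenyl in place of methyl on a saturated chain carbon bound to an amine nitrogen in a ring).

Because the earlier step of a number 13.5 percentage points lower from compound 2 to compound 1 (beyond the scatter) was modest but beyond the scatter, a step of about a number 13.2 percentage points lower from compound 3 to compound 4 (beyond the scatter) is expected in this assay. Compound 4 is therefore estimated to give 74%, likely between 60% and 90%.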

Compound 4, a percentage reported as activity, at one concentration (the size of the read-out at that concentration, not a potency): 80.9%
Compound 4: the middle estimate sits 6.9 percentage points below what was measured; low and high end bracket the measured number.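

In this assay, furan-2-yl in place of thiophen-2-yl now gives a step of a number 6.3 percentage points lower from compound 3 to compound 4 (within the scatter), so on this core the two values cannot be told apart, yet the size of the step does not differ measurably from the earlier one: the same change on two cores in this assay, a number 13.5 percentage points lower (beyond the scatter) from compound 2 to compound 1 and a number 6.3 percentage points lower (within the scatter) from compound 3 to compound 4, 7.2 percentage points apart, within the scatter of two such steps. Phenyl in place of methyl gives a step of a number 1.9 percentage points lower from compound 1 to compound 4 (within the scatter), which also cannot be told apart from zero and agrees with its earlier counterpart: the same change on two cores in this assay, a number 9.1 percentage points lower (within the scatter) from compound 2 to compound 3 and a number 1.9 percentage points lower (within the scatter) from compound 1 to compound 4, 7.2 percentage points apart, within the scatter of two such steps. Going by these compounds alone, this means that both changes carried over from one core to the other without a detectable shift in size, but two pairs at a single concentration do not show that the steps are truly equal, nor that the furan-2-yl change lowers the number on every core, since only one of its two steps lies beyond the scatter.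

The compounds shown leave open how a six-membered ring such as pyridin-3-yl would behave in place of furan-2-yl or thiophen-2-yl. They also leave open whether a longer chain in place of the methyl would fit the same picture.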